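Aryl extension on the benzyl arm of the series

The compounds below may be only part of what the source reports. "The series", "measured", "known", "first", "only" and "open" are said of these compounds alone.

Compound 1 `COC(=O)/C=C/c1cccc(N(Cc2ccc(/C=C/c3scnc3C)cc2)C(=O)C2CCCCC2)c1` gives 227 nM in an assay on isolated protein with Bile acid receptor (Homo sapiens) as the target; on this read-out lower numbers stand for an effect already at smaller amounts and higher numbers for an effect only at larger amounts of compound. Compound 2 `COC(=O)/C=C/c1cccc(N(Cc2ccccc2)C(=O)C2CCCCC2)c1` is reported in this assay only as a limit of > 1000 nM. Compound 3 `COC(=O)/C=C/c1cccc(N(Cc2ccc(-c3cccc(C(C)=O)c3)cc2)C(=O)C2CCCCC2)c1` gives 227 nM in this assay, so that it stands level with compound 1, and no change at the digits printed from compound 1 to compound 3 (within the scatter). Compound 4 `COC(=O)/C=C/c1cccc(N(Cc2ccc(/C=C/c3c(Cl)cccc3Cl)cc2)C(=O)C2CCCCC2)c1` carries 2-(2,6-dichlorophenyl)ethenyl in place of 3-acetylphenyl on an aromatic carbon. The steps bearing on this exchange are an at least 4.4-fold lower number from compound 2 to compound 3 (0.64 log units; beyond the scatter) and an at least 4.4-fold higher number from compound 1 to compound 2 (0.64 log units; beyond the scatter), both bounded by the limit of > 1000 nM in this assay, at which 1 of the 3 values shown sits, together with no change at the digits printed from compound 1 to compound 3 (within the scatter), which shows two unlike large groups at this carbon giving the same number. A third large group at the same place is therefore expected to leave this assay unchanged beyond the scatter, a 1.1-fold higher number from compound 3 to compound 4 (0.04 log units; within the scatter). Compound 4 is estimated at 250 nM, within 80 nM to 800 nM.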

Compound 4, half-maximal effective concentration: 150 nM
Compound 4: middle estimate off by 1.7-fold (0.22 log units), on the high side; measured number inside the range.
By their numbers in this assay, from the lowest: compounds 4, 1 and 3 (each within the scatter of the next). At a limit, above all of these: compound 2.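

In this assay, 2-(2,6-dichlorophenyl)ethenyl at this carbon stays level with both earlier large groups: a 1.5-fold lower number from compound 3 to compound 4 (0.18 log units; within the scatter), and a 1.5-fold lower number from compound 1 to compound 4 (0.18 log units; within the scatter). A group with 0 hydrogen-bond acceptors therefore serves as well as 3-acetylphenyl, and 2,6-dichlorophenyl can replace 4-methyl-1,3-thiazol-5-yl on the ethenyl chain without a shift beyond the scatter. The separation from the hydrogen compound, an at least 6.6-fold lower number from compound 2 to compound 4 (0.82 log units; beyond the scatter), is bounded by a limit, that of compound 2: the limit of > 1000 nM in this assay, at which 1 of the 4 values shown sits.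

As far as these compounds go, whether a carboxylic acid or an amine on this large group keeps the number remains open. Also open, from the compounds shown here alone, is whether a small group such as methyl at this carbon is enough.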